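Halogen swap on the pyridine ring of an oxadiazole ketone

A few compounds are considered here, and "the series" means these few. Any claim that something is new, unique, unknown or untested is made for them only; others in the source may bear on it.

Measured compounds:
- compound 1, `O=C(CCCCCCc1ccccc1)c1noc(-c2ccccn2)n1`, 1.1 nM
- compound 2, `O=C(CCCCCCc1ccccc1)c1nc(-c2cccc(Cl)n2)no1`, 1 nM

Compound 2 gives the lowest number of the two in an assay for inhibition of Fatty-acid amide hydrolase 1 (Rattus norvegicus) (a higher number here means a weaker inhibitor, a lower number a stronger inhibitor), but its nearest neighbour, compound 1, sits only marginally higher in this assay with 1.1 nM, a gap that falls within the scatter of repeated measurements. So the two compounds show no difference that can be trusted; compound 1 carries the unsubstituted pyridine, compound 2 the chloro-bearing one, and both behave alike.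

The next compound, compound 3, `O=C(CCCCCCc1ccccc1)c1nc(-c2cccc(I)n2)no1`, has not yet been measured in this assay. It differs from compound 2 by iodo in place of chloro on an aromatic carbon. Among the compounds with values here, no pair measured so far shows what such a halogen exchange does here, so there is no step to lean on. Given that the bare ring of compound 1 and the chloro ring of compound 2 give the same result, the expectation is a small step, a 1.5-fold higher number from compound 2 to compound 3 (0.18 log units; within the scatter), hardly beyond the scatter and without a firm direction. Compound 3 is therefore estimated at 1.5 nM, within a range of 0.5 nM to 5 nM.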

Compound 3, inhibition constant: 1 nM
For compound 3 the middle estimate is 1.5-fold (0.18 log units) above the measured one; the range from low to high includes it.
By their numbers in this assay, from the lowest: compounds 2, 3 and 1 (each within the scatter of the next).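

Within the data shown here, this pair gives the first direct reading of a halogen exchange at this place: in this assay, going from 6-chloropyridin-2-yl to 6-iodopyridin-2-yl gives no change at the digits printed from compound 2 to compound 3 (within the scatter). The carbon next to the ring nitrogen therefore carries either chloro or iodo without a difference that this measurement can resolve, so the identity of these two halogens does not separate the compounds, although the exchange replaces one heavy atom with another and adds no hydrogen-bond donor, acceptor, ring or net charge. Nothing available gives a measured property that bears on this equivalence, and the result stands as an observation without an explanation.

As far as these compounds go, the pair covers only chloro and iodo, so it remains open whether the same insensitivity would extend to a fluoro group, or to something of a different kind at this carbon, such as an amine or a carboxylic acid. From the compounds shown here alone, it is equally open whether the equivalence of the two halogens would hold with a shorter or longer chain between the phenyl ring and the carbonyl.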